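The source may report more compounds than this note shows. Statements on the series, on what has been measured and on what is new or still open speak of the compounds shown alone.

Compound 1 `CCNC(=O)c1cc(N)c(Nc2ccc(C#N)cc2)cc1Oc1c(C)cc(CCC#N)cc1C`: 105000 nM
Compound 2 `Cc1cc(CCC#N)cc(C)c1Oc1cc(Nc2ccc(C#N)cc2)c(N)cc1C(=O)NC1CC1`: 121000 nM
Compound 3 `Cc1cc(CCC#N)cc(C)c1Oc1cc(Nc2ccc(C#N)cc2)c(N)cc1C(=O)NC(C)C`: 184000 nM

These three compounds share one core and differ only in the group carried on the amide nitrogen. In an ADME assay on TZM cells (Homo sapiens) for cytotoxicity, with a stated time of 1 days (on this read-out higher numbers stand for lower toxicity in this test and lower numbers for higher toxicity in this test), compound 1 gives a number from which the other two depart only within the scatter: a 1.2-fold higher number from compound 1 to compound 2 (0.06 log units; within the scatter) and a 1.8-fold higher number from compound 1 to compound 3 (0.24 log units; within the scatter), and between the other two a 1.5-fold higher number from compound 2 to compound 3 (0.18 log units; within the scatter). Nothing separates the three beyond the usual noise of the measurement.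

Compound 4 `Cc1cc(CCC#N)cc(C)c1Oc1cc(Nc2ccc(C#N)cc2)c(N)cc1CNC1CC1` alters compound 1 at a different point: (cyclopropylamino)methyl in place of ethylcarbamoyl on an aromatic carbon. The carbonyl leaves and a saturated carbon enters between the ring and the nitrogen. Within the data shown here, none of the measured steps touches the carbonyl; each only exchanges the group on the amide nitrogen, and each stays within the scatter. Among the measured compounds shown here, no measured step therefore bears directly on this change, and the expectation rests only on the similar numbers of compounds 1 to 3. Compound 4 is expected to give 90000 nM (range 30000 nM to 250000 nM), an expected step of a 1.2-fold lower number from compound 1 to compound 4 (0.07 log units; within the scatter).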

Compound 4, half-maximal cytotoxic concentration: 25500 nM
Compound 4: middle estimate off by 3.5-fold (0.55 log units), on the high side; the whole stated range lies above it.
By their numbers in this assay, from the lowest: compound 4; then compounds 1, 2 and 3 (each within the scatter of the next).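

Replacing the amide with (cyclopropylamino)methyl on this aromatic carbon moves the number in this assay beyond the scatter and toward higher toxicity in this test, with a 4.1-fold lower number from compound 1 to compound 4 (0.61 log units; beyond the scatter) and a 7.2-fold lower number from compound 3 to compound 4 (0.86 log units; beyond the scatter) and a 4.7-fold lower number from compound 2 to compound 4 (0.68 log units; beyond the scatter). The last of these steps is the most telling: the cyclopropyl group stays on the nitrogen, and the carbonyl gives way to a saturated carbon, so this link to the ring matters in a way that exchanging groups on the amide nitrogen did not reveal. No measurement shown here accounts for the shift.

The compounds shown leave open whether an (ethylamino)methyl or (isopropylamino)methyl group would match compound 4. They also leave open whether a carboxylic acid on this aromatic carbon would group with the amides or with the amine.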